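The compounds below may be only part of what the source reports. "The series", "measured", "known", "first", "only" and "open" are said of these compounds alone.

Measured in a functional assay on a cell-free system (plasma, Oryctolagus cuniculus) for inhibition, with stated times of 5 min, 1 min and 6 min; a higher number here means a weaker inhibitor, a lower number a stronger inhibitor:
- compound 1 `CCOC(=O)c1c(C)nc(-c2cccc(C#N)c2)n1C(C)C`: 9260 nM
- compound 2 `CCOC(=O)c1c(C)nc(-c2cccc(C#N)c2)n1OC(C)C`: 6740 nM
- compound 3 `CCOC(=O)c1c(C)nc(-c2cccc(C#N)c2)n1OCCC(=O)O`: > 30000 nM

Compound 3 gives no number, only a limit of the assay, > 30000 nM. The next compound, compound 4 `CCOC(=O)c1c(C)nc(-c2cccc(C#N)c2)n1OCc1ccc(F)cc1`, has 4-fluorophenyl in place of carboxymethyl on a saturated chain carbon bound to an oxygen on an aromatic ring.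

Within the data shown here, three measured steps bear on this change. The step of a 1.4-fold lower number from compound 1 to compound 2 (0.14 log units; within the scatter) changes the isopropyl group for isopropoxy. The steps of an at least 3.2-fold higher number from compound 1 to compound 3 (0.51 log units; beyond the scatter) and an at least 4.4-fold higher number from compound 2 to compound 3 (0.64 log units; beyond the scatter) lead to the carboxylic acid, and each is only a bound. Compound 4 no longer carries that acid, so a return towards compound 1 and compound 2 is expected in this assay. Among the measured compounds shown here, no measured compound carries a 4-fluorophenyl group, which leaves the size uncertain. The expected change is an at least 6.0-fold lower number from compound 3 to compound 4 (0.77 log units; beyond the scatter), a lower number. For compound 4 the estimate is 5000 nM, with an expected range from 1200 nM to 20000 nM.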

Compound 4, half-maximal inhibitory concentration: 5880 nM
Estimate against measurement, compound 4: 1.2-fold (0.07 log units) below, within the range that was stated.
By their numbers in this assay, from the lowest: compounds 4, 2 and 1 (each within the scatter of the next). At a limit, above all of these: compound 3.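

Replacing carboxymethyl with 4-fluorophenyl on a saturated chain carbon bound to an oxygen on an aromatic ring gives an at least 5.1-fold lower number from compound 3 to compound 4 (0.70 log units; beyond the scatter) in this assay, a step that is only a bound, as compound 3 has no number: the limit of > 30000 nM in this assay, at which 1 of the 4 values shown sits. Against the compounds without the acid, the new group brings no readable change, with a 1.1-fold lower number from compound 2 to compound 4 (0.06 log units; within the scatter) and a 1.6-fold lower number from compound 1 to compound 4 (0.20 log units; within the scatter). The one-place comparisons thus show that a six-membered aromatic ring can stand on this chain with the value staying within the scatter of compound 2, and among the compounds shown only compound 3, with its carboxylic acid, goes against that level.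

From the compounds shown here alone, what an amine, an amide or an unsubstituted benzyl group would do on this oxygen remains open. So does the true size of the step from compound 3, whose value is only a limit.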